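Thiol amide series: hydrogen in place of cyclohexyl

The source may report more compounds than this note shows. Statements on the series, on what has been measured and on what is new or still open speak of the compounds shown alone.

Compound 1 `O=C(NCCCCCCSSCCCCCCNC(=O)c1cc(-c2ccncc2)n[nH]1)c1cc(-c2ccncc2)n[nH]1` – 8930 nM
Compound 2 `O=C(NCCCCCCS)c1cc(C2CCCCC2)n[nH]1` – > 50000 nM

All values come from a functional assay on HCT-116 cells (Homo sapiens) for inhibition, read by MTT assay, with a stated time of 96 h (a lower number here means a stronger inhibitor of growth, a higher number a weaker inhibitor of growth), as the single read-out for this series. For compound 2 the entry > 50000 nM is a limit of the assay and gives no exact position.

Compound 3 `O=C(NCCCCCCS)c1ccn[nH]1` differs from compound 2 by hydrogen in place of cyclohexyl on an aromatic carbon and this is hydrogen in place of cyclohexyl on an aromatic carbon. Going by the values given here, no measured pair shows this change alone. The expected shift is a number no higher from compound 2 to compound 3 (the limit leaves the size open) and no clear direction beyond the scatter is expected. For compound 3 the estimated concentration is 50000 nM with an expected range of 20000 nM to 100000 nM in this assay once measured.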

Compound 3, concentration for 50% growth inhibition: > 50000 nM
Compound 3: no number, only a limit (the forecaster's own chance of this, stated with the estimate: 60%); the middle value lies on the limit itself.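

Going by these compounds alone, compound 2 and compound 3 both stand at a limit of the assay, so no step between them can be read: the limit of > 50000 nM in this assay, at which 2 of the 3 values shown sit. The compounds shown leave open whether hydrogen in place of cyclohexyl alters growth inhibition at all.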